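The compounds below may be only part of what the source reports. "The series", "measured", "known", "first", "only" and "open" are said of these compounds alone.

Measured in a functional assay on thoracic aorta (Rattus norvegicus) for inhibition; a lower number here means that less compound is needed, a higher number that more compound is needed for the effect:
compound 1 `CC1(C)CC(NC(=S)Nc2cccc(C#N)c2)c2cc(NS(C)(=O)=O)ccc2O1` gives 9800 nM;
compound 2 `CC1(C)CC(NC(=O)Nc2cccc(C#N)c2)c2cc(NS(C)(=O)=O)ccc2O1` gives 9300 nM;
compound 3 `CCS(=O)(=O)Nc1ccc2c(c1)C(NC(=S)Nc1cccc(C#N)c1)CC(C)(C)O2` gives 12100 nM.

Compound 3 lies within the scatter of both compound 1 and compound 2, so the three compounds cannot be told apart on these numbers. Going by the values given here, the only single-point step among them, a 1.2-fold higher number from compound 1 to compound 3 (0.09 log units; within the scatter), concerns the sulfonamide chain and not the aryl end of the thiourea. Compound 4 `CCS(=O)(=O)Nc1ccc2c(c1)C(NC(=S)Nc1ccc(Cl)cc1)CC(C)(C)O2` differs from compound 3 at that other end: 4-chlorophenyl in place of 3-cyanophenyl on an amide-type nitrogen. Among the compounds with values here, no measured step touches this part of the molecule, so nothing in the data points to a direction, and the expected step is a 1.0-fold lower number from compound 3 to compound 4 (0.00 log units; within the scatter), with wide uncertainty. Compound 4 is therefore estimated at 12000 nM, with a range from 3000 nM to 48000 nM.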

Compound 4, half-maximal effective concentration: 5100 nM
Beside the measured number, compound 4's estimate is 2.4-fold (0.37 log units) above it, and the stated range covers the measured number.
By their numbers in this assay, from the lowest: compounds 4, 2, 1 and 3 (each within the scatter of the next, the first and the last beyond it).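

In this assay, going by these compounds alone, the exchange on the amide-type nitrogen gives a 2.4-fold lower number from compound 3 to compound 4 (0.38 log units; beyond the scatter), a modest step, whereas the one step among the earlier compounds, at the sulfonamide chain, stayed within the scatter. This makes the aryl end of the thiourea the only place shown where a single change moves the number beyond the scatter. No measurement available here bears on why the number moves.

The compounds shown leave open whether the chlorine or its location on the ring matters. They also leave open how 3-chlorophenyl, 4-cyanophenyl or plain phenyl would read on that nitrogen.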